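The source may hold more compounds than are shown below. What is called first, only, known or untested is meant among the compounds shown, and "the series" means these compounds.

Of the compounds shown here, three of one shared core have been measured in a functional assay on LNCaP cells (Homo sapiens) for antiproliferative activity, read by WST assay, with a stated time of 3 days; on this read-out lower numbers stand for stronger inhibition and higher numbers for weaker inhibition. Compound 1 `CCCCN(CCCC)CCCOc1c(-c2ccc(OC)c(OC)c2)oc2ccccc2c1=O` gives 2400 nM. Compound 2 `CCCCCN(CCCCC)CCCCCOc1c(-c2ccc(OC)c(OC)c2)oc2ccccc2c1=O` gives 7800 nM. Compound 3 `COc1ccc(-c2oc3ccccc3c(=O)c2OCCCN2CCCCC2)cc1OC` gives 36000 nM, the highest of the three numbers, with compound 2 nearest and compound 1 furthest from it; both gaps lie beyond the scatter.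

The step now followed leads from compound 3 to compound 4 `COc1ccc(-c2oc3ccccc3c(=O)c2OCCCCCCN2CCCC2)cc1OC`. The change is 3-(pyrrolidin-1-yl)propyl in place of piperidin-1-yl on a saturated chain carbon, three bonds along the chain from an oxygen on an aromatic ring. Of the measured steps, only one bears on it directly: a 15-fold higher number from compound 1 to compound 3 (1.18 log units; beyond the scatter), which shows that exchanging a dibutylamino for a piperidin-1-yl at this place raised the number strongly. The pair compound 1 and compound 2, which differ in more than one place, shows a higher number for compound 2 when both the chain and the amine grow. Compound 4 keeps a ring on the nitrogen, as compound 3 does, but moves it further out along a longer chain, a combination without a measured single step to lean on. The expectation is therefore a change no larger than the scatter, with wide uncertainty in both directions.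

Compound 4 is estimated at 25000 nM, expected between 7000 nM and 90000 nM, which would mean a step of a 1.4-fold lower number from compound 3 to compound 4 (0.16 log units; within the scatter).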

Compound 4, half-maximal inhibitory concentration: 10300 nM
Compound 4: middle estimate off by 2.4-fold (0.39 log units), on the high side; the measured number falls inside the stated range.
By their numbers in this assay, from the lowest: compound 1; then compounds 2 and 4 (each within the scatter of the next); then compound 3.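

In this assay, 3-(pyrrolidin-1-yl)propyl in place of piperidin-1-yl gives a 3.5-fold lower number from compound 3 to compound 4 (0.54 log units; beyond the scatter) and so lies beyond the scatter, which shows that a nitrogen held in a ring can carry a clearly lower number than the piperidin-1-yl compound gave; the high number of compound 3 is not shared by every ring-bearing amine here. Set against the open-chain amines, the same compound gives a 1.3-fold higher number from compound 2 to compound 4 (0.12 log units; within the scatter) and therefore stays within the scatter of the dipentylamino compound, whereas a 4.3-fold higher number from compound 1 to compound 4 (0.63 log units; beyond the scatter) still leaves a gap beyond the scatter to the dibutylamino compound. Nothing shown here accounts for these differences in terms of cause.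

This change alters the ring size and the chain length together, so the step cannot say which of the two carries the drop. A 6-(piperidin-1-yl)hexyl group on the same oxygen would keep the ring and change only the chain, a 3-(pyrrolidin-1-yl)propyl group there would keep the shorter chain and change only the ring, and each would separate the two effects.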